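Ethoxycarbonyl in place of phenyl on compound 2

This account rests on a few compounds, and the source may have more. Where it says the series, first, only, none or still open, it means among the compounds named here.

In a functional assay on B16 cells (Mus musculus) for inhibition (a higher number here means a weaker inhibitor, a lower number a stronger inhibitor), compound 2 (`COc1cc(/C=C/C(=O)c2cccc(NC(=O)c3ccccc3)c2)ccc1O`) gives 0.82 ug/mL, and compound 1 (`COc1cc(/C=C/C(=O)c2cccc(NC(=O)c3c(Cl)cccc3Cl)c2)ccc1O`) gives 1.58 ug/mL. Among the measured compounds shown here, these are the only two numbers so far, and they lie within the scatter of each other, so the two cannot be told apart.

Compound 3 (`CCOC(=O)C(=O)Nc1cccc(C(=O)/C=C/c2ccc(O)c(OC)c2)c1`) is not yet measured. It carries ethoxycarbonyl in place of phenyl on a carbonyl carbon.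

For the measured compounds named here, one measured step bears on this, at the same place: a 1.9-fold lower number from compound 1 to compound 2 (0.28 log units; within the scatter), with phenyl in place of 2,6-dichlorophenyl. That step stays within the scatter, but both of its compounds keep the aromatic ring on that carbonyl carbon. Going by the values given here, no measured compound lacks it, so the data do not test the change directly.

Among the compounds with values here, with only that step as a guide, no step clearly beyond the scatter is expected in this assay, with a slight lean toward a higher number. The expected step is a 1.7-fold higher number from compound 2 to compound 3 (0.23 log units; within the scatter). For compound 3 the estimated value is 1.4 ug/mL, with an expected range of 0.45 ug/mL to 4.5 ug/mL.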

Compound 3, half-maximal inhibitory concentration: 7.03 ug/mL
For compound 3 the middle estimate is 5.0-fold (0.70 log units) below the measured one; the measured number lies above the stated range.
By their numbers in this assay, from the lowest: compounds 2 and 1 (each within the scatter of the next); then compound 3.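

In this assay the ethoxycarbonyl group on the carbonyl carbon gives an 8.6-fold higher number from compound 2 to compound 3 (0.93 log units; beyond the scatter) and, set against the 2,6-dichlorophenyl group, a 4.4-fold higher number from compound 1 to compound 3 (0.65 log units; beyond the scatter) at the same place, so compound 3 is the weakest of the three. The earlier pair, both with an aromatic ring on this carbonyl carbon, could not be told apart, whereas this first replacement without a ring moves the number beyond the scatter, showing that the position does respond to a change of group and that an exchange of phenyl for ethoxycarbonyl is not tolerated without loss in this series. No available data account for this loss.

The compounds shown leave open whether the loss goes with removing the aromatic ring or with bringing in the ester, since compound 3 differs from compound 2 in both respects at once. A cyclohexyl ring, a pyridyl ring, a plain ethyl chain or the free carboxylic acid at this place would begin to separate those two readings.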